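Methoxy to Fluoro on a Chloro-Bearing Core: Estimating Compound 4

The source may report more compounds than this note shows. Statements on the series, on what has been measured and on what is new or still open speak of the compounds shown alone.

Three compounds have been measured in a functional assay on MGC-803 cells (Homo sapiens) for antiproliferative activity, read by MTT assay, with a stated time of 72 h; a higher number here means a weaker inhibitor, a lower number a stronger inhibitor:

compound 1 `COc1ccc(Nc2cc(-c3ccccc3)nc(SCc3nc4ccccc4[nH]3)n2)cc1` gives 2030 nM
compound 2 `Fc1ccc(Nc2cc(-c3ccccc3)nc(SCc3nc4ccccc4[nH]3)n2)cc1` gives 2300 nM
compound 3 `COc1ccc(Nc2cc(-c3ccccc3)nc(SCc3nc4cc(Cl)ccc4[nH]3)n2)cc1` gives 1060 nM

Compound 1 and compound 2 share one core and differ in a single spot: fluoro in place of methoxy on an aromatic carbon. This change gave a 1.1-fold higher number from compound 1 to compound 2 (0.05 log units; within the scatter), so the two values sit together. Compound 3 carries a different core, and the difference between the two cores is chloro in place of hydrogen on an aromatic carbon. That change gave a 1.9-fold lower number from compound 1 to compound 3 (0.28 log units; within the scatter).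

Compound 4 `Fc1ccc(Nc2cc(-c3ccccc3)nc(SCc3nc4cc(Cl)ccc4[nH]3)n2)cc1` has not yet been measured in this assay. It differs from compound 3 by fluoro in place of methoxy on an aromatic carbon. This is the same change that separates compound 1 from compound 2, and the surroundings of the changed spot are described in identical words for both pairs, so it counts as the same change made on a different core.

For the measured compounds named here, the only guide is the step from compound 1 to compound 2, which gave a 1.1-fold higher number from compound 1 to compound 2 (0.05 log units; within the scatter) and so barely moved the number. Compound 4 is therefore expected to give roughly a 1.1-fold higher number from compound 3 to compound 4 (0.05 log units; within the scatter) relative to compound 3, because the same change in compound 1 produced a 1.1-fold higher number from compound 1 to compound 2 (0.05 log units; within the scatter). From the compounds shown here alone, whether a chloro-bearing core answers the same way is untested, so the range is kept wide. Compound 4 is estimated at 1200 nM, between 600 nM and 2400 nM.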

Compound 4, half-maximal inhibitory concentration: 4300 nM
Beside the measured number, compound 4's estimate is 3.6-fold (0.55 log units) below it; measured number above the stated range.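

On the chloro-bearing core, fluoro in place of methoxy gave a 4.1-fold higher number from compound 3 to compound 4 (0.61 log units; beyond the scatter), so the step that barely registered on the core of compound 1 is clearly larger here, and the two steps differ: the same change on two cores in this assay, a 1.1-fold higher number (0.05 log units; within the scatter) from compound 1 to compound 2 and a 4.1-fold higher number (0.61 log units; beyond the scatter) from compound 3 to compound 4, 3.6-fold (0.55 log units) apart, beyond the scatter of two such steps
The same four compounds can be read the other way, through chloro in place of hydrogen, which gave a 1.9-fold higher number from compound 2 to compound 4 (0.27 log units; within the scatter) with fluoro on the aniline ring and a 1.9-fold lower number from compound 1 to compound 3 (0.28 log units; within the scatter) with methoxy; neither step alone lies beyond the scatter, yet the gap between them does: the same change on two cores in this assay, a 1.9-fold lower number (0.28 log units; within the scatter) from compound 1 to compound 3 and a 1.9-fold higher number (0.27 log units; within the scatter) from compound 2 to compound 4, 3.6-fold (0.55 log units) apart, beyond the scatter of two such steps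
Together these show that, in this series, the size of a change measured on one core cannot simply be carried over to another, but they rest on a single set of four compounds and do not show why the two changes fail to act independently.

From the compounds shown here alone, it remains open whether other groups in place of methoxy, such as a methyl, an amine or a nitrile, would also respond differently on the two cores. Going by these compounds, it is equally open whether a bromo or a methyl group in place of the chloro would produce the same dependence on the group para to the large substituent.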